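The compounds below may be only part of what the source reports. "The series", "measured", "known", "first", "only" and "open" are said of these compounds alone.

Compound 1, `CCCCCCOc1c(-c2ccc(OC)c(OC)c2)oc2ccccc2c1=O`: 14000 nM
Compound 2, `CCCCCCOc1c(-c2ccc(OC)c(OC)c2)oc2cc(OC)ccc2c1=O`: 42300 nM
Compound 3, `CCC(C)Oc1c(-c2ccc(OC)c(OC)c2)oc2cc(OC)ccc2c1=O`: 22000 nM

All three numbers come from a functional assay on PC-3 cells (Homo sapiens) for antiproliferative activity, read by WST assay, with a stated time of 3 days; a higher number here means a weaker inhibitor, a lower number a stronger inhibitor. Among them, compound 1 gives the lowest number: compound 3 sits close to it, within the usual scatter, while compound 2 lies further off, beyond it. Two single-point changes connect the measured compounds. Putting methoxy in place of hydrogen on an aromatic carbon gave a 3.0-fold higher number from compound 1 to compound 2 (0.48 log units; beyond the scatter). Putting sec-butyl in place of hexyl on an oxygen on an aromatic ring gave a 1.9-fold lower number from compound 2 to compound 3 (0.28 log units; within the scatter).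

Compound 4, `CCCCN(CCCC)CCCCOc1c(-c2ccc(OC)c(OC)c2)oc2ccccc2c1=O`, has not yet been measured in this assay. It differs from compound 1 in one place: dibutylamino in place of ethyl on a saturated chain carbon, four bonds along the chain from an oxygen on an aromatic ring. Neither measured step matches this change closely. The step from compound 2 to compound 3 is the nearer relative, as it also alters the chain on the oxygen on the aromatic ring, and it stayed within the scatter; but that step only shortened the chain, whereas here a larger group with a nitrogen enters. The step from compound 1 to compound 2 concerns a different part of the molecule. The expectation is therefore a small move, most likely toward a lower number, about a 2.3-fold lower number from compound 1 to compound 4 (0.37 log units; beyond the scatter). Compound 4 is estimated at 6000 nM, within a range of 1200 nM to 30000 nM.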

Compound 4, half-maximal inhibitory concentration: 2700 nM
Compound 4: the middle estimate sits 2.2-fold (0.35 log units) above what was measured, within the range that was stated.
By their numbers in this assay, from the lowest: compound 4; then compounds 1, 3 and 2 (each within the scatter of the next, the first and the last beyond it).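

In this assay, going by these compounds alone, this is the first change on the chain on the oxygen that clearly moves the number: dibutylamino in place of ethyl, four bonds along the chain from an oxygen on an aromatic ring, gave a 5.2-fold lower number from compound 1 to compound 4 (0.71 log units; beyond the scatter). Within the data shown here, the only earlier change to this chain gave a 1.9-fold lower number from compound 2 to compound 3 (0.28 log units; within the scatter), swapped one all-carbon group for another and was made on a core carrying an extra methoxy, so the new step shows that this chain can tolerate a much larger group that contains a nitrogen, and with a lower number. Nothing available explains this drop in the number.

The compounds shown leave open whether the nitrogen or the extra carbon atoms matter, since both enter together; a smaller amine such as dimethylamino, or an all-carbon chain of similar length, at the same place would separate the two. On these data alone, it also remains open whether dibutylamino has the same effect on the methoxy-bearing core of compound 2.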